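Shorter alkyl on the benzimidazole carbon: compound 3

This account rests on a few compounds, and the source may have more. Where it says the series, first, only, none or still open, it means among the compounds named here.

Compound 2 `CCCCOC(=O)NS(=O)(=O)c1ccc(CCC)cc1-c1ccc(Cn2c(C(C)(C)C)nc3ccccc32)cc1` gives the lowest of the two numbers in an assay on membranes from HEK293 cells for displacement of a labelled ligand from Type-2 angiotensin II receptor (Homo sapiens), read by radioligand binding (a lower number here means a stronger inhibitor, a higher number a weaker inhibitor), with compound 2 at 5.3 nM; compound 1 `CCCCOC(=O)NS(=O)(=O)c1ccc(CCC)cc1-c1ccc(Cn2c(CCCC)nc3ccccc32)cc1` gives 9.2 nM, and the step of a 1.7-fold lower number from compound 1 to compound 2 (0.24 log units; within the scatter) lies within the scatter. Compound 3 `CCCCOC(=O)NS(=O)(=O)c1ccc(CCC)cc1-c1ccc(Cn2c(CC)nc3ccccc32)cc1` differs from compound 2 by ethyl in place of tert-butyl on an aromatic carbon. Within the data shown here, only that single step bears on this change, and it was small, so compound 3 is expected to stay near compound 2, with a step of about a 1.5-fold higher number from compound 2 to compound 3 (0.18 log units; within the scatter) in this assay and no clear direction beyond the scatter. Compound 3 is therefore estimated at 8 nM, within 3 nM to 25 nM.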

Compound 3, inhibition constant: 11 nM
Compound 3: the middle estimate sits 1.4-fold (0.14 log units) below what was measured; low and high end bracket the measured number.
By their numbers in this assay, from the lowest: compounds 2, 1 and 3 (each within the scatter of the next, the first and the last beyond it).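

Among these compounds, replacing tert-butyl with ethyl on this aromatic carbon in this assay gives the first step at this position that passes the scatter, though only modestly (a 2.1-fold higher number from compound 2 to compound 3 (0.32 log units; beyond the scatter)). Ethyl and butyl cannot be told apart here (a 1.2-fold higher number from compound 1 to compound 3 (0.08 log units; within the scatter)), so the measured gap separates tert-butyl from ethyl, while tert-butyl and butyl stay within the scatter of each other. No measurement at hand accounts for this gap. The compounds shown leave open how methyl or a cyclopropyl ring on this carbon would read. They also leave open whether a chain ending in an amine or a carboxylic acid would keep the number in this range.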